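Aryl for alkyl on the five-membered ring: cytotoxicity outlook

A few compounds are considered here, and "the series" means these few. Any claim that something is new, unique, unknown or untested is made for them only; others in the source may bear on it.

Two compounds of this series have a number in an ADME assay on HeLa cells (Homo sapiens) for cytotoxicity, read by sulforhodamine B assay, with a stated time of 48 h, tested at 10 uM; a lower number here means less inhibition, a higher number more inhibition at the concentration tested (going by the name of the read-out). Compound 1 `CCCCCCCc1cn(C(c2ccccc2)c2cc3cc(Br)ccc3nc2OC)nn1` gives 9.7%. Going by the values given here, compound 2 `CCCc1cn(C(c2ccccc2)c2cc3cc(Br)ccc3nc2OC)nn1` gives -2.25%, the lowest of the two numbers, with compound 1 as its only neighbour. Among the compounds with values here, the single step with both ends measured is a number 12 percentage points lower from compound 1 to compound 2 (beyond the scatter), which goes with hydrogen in place of butyl on a saturated chain carbon, three bonds along the chain from an aromatic carbon.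

Compound 3 `COc1nc2ccc(Br)cc2cc1C(c1ccccc1)n1cc(-c2ccc(F)cc2)nn1` is not yet measured in this assay. Against compound 2 the change is 4-fluorophenyl in place of propyl on an aromatic carbon, on an aromatic carbon of a five-membered aromatic ring with 3 nitrogen, next to the ring nitrogen. Within the data shown here, no measured step shows an aromatic group entering at this carbon; the one known step concerns chain length only, and in it the compound with the larger group, compound 1, stands higher. The expectation is therefore a modest rise from compound 2 to compound 3, about a number 9.3 percentage points higher from compound 2 to compound 3 (within the scatter), close to the edge of the scatter. For compound 3 the estimate in this assay is 7%, within -8% to 22%.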

Compound 3, a percentage reported as inhibition, at one concentration (the size of the read-out at that concentration, not a potency): 4.27%
For compound 3 the middle estimate is 2.7 percentage points above the measured one; measured number inside the range.
By their numbers in this assay, from the lowest: compounds 2, 3 and 1 (each within the scatter of the next, the first and the last beyond it).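

In this assay, going by these compounds alone, the first aromatic group on this aromatic carbon of the five-membered aromatic ring with 3 nitrogen, 4-fluorophenyl, gives a number 6.5 percentage points higher from compound 2 to compound 3 (within the scatter) against propyl and a number 5.4 percentage points lower from compound 1 to compound 3 (within the scatter) against heptyl. Compound 3 therefore cannot be told apart from either chain compound, even though the two chains differ from each other beyond the scatter, so swapping a chain for this aromatic ring does not carry the number outside the span set by propyl and heptyl. No measurement at hand accounts for this outcome.

With a single aromatic example, the compounds shown leave open whether the fluorine plays any part in the reading, which a plain phenyl or a 4-methoxyphenyl at the same carbon would help to separate from the effect of the ring itself. Also open, from the compounds shown here alone, is how this assay responds to a group of another kind at this carbon, such as a pyridine ring, or a chain ending in an amine or a carboxylic acid.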